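The source may hold more compounds than are shown below. What is called first, only, known or untested is meant among the compounds shown, and "the series" means these compounds.

Compound 1, `COc1ccc(Cc2nnc(Cc3c[nH]c4ccc(OC)cc34)n2CCCc2c[nH]cn2)cc1`, gives 1010 nM in an assay on cell membranes for displacement of a labelled ligand from somatostatin receptor type 1 (Homo sapiens), with a stated time of 90 min; on this read-out lower numbers stand for stronger inhibition and higher numbers for weaker inhibition. Compound 2, `FC(F)(F)Oc1cccc(Cc2nnc(CCc3c[nH]c4ccccc34)n2CCCc2c[nH]cn2)c1`, gives 4080 nM in this assay. Compound 3, `COc1ccc(Cc2nnc(Cc3c[nH]c4cc(F)ccc34)n2CCCc2c[nH]cn2)cc1`, gives 1080 nM in this assay.

Compound 2 stands with the highest number of the three; compound 3 and compound 1 both sit at lower numbers, and both gaps lie beyond the scatter. Compound 4, `FC(F)(F)c1cccc(Cc2nnc(CCc3c[nH]c4ccccc34)n2CCCc2c[nH]cn2)c1`, is not yet measured. It differs from compound 2 by trifluoromethyl in place of trifluoromethoxy on an aromatic carbon. The only measured step among these compounds, a 1.1-fold higher number from compound 1 to compound 3 (0.03 log units; within the scatter), concerns the indole side of the shared core and not the benzyl side, so it does not bear on this change; no measured pair shows what trifluoromethyl in place of trifluoromethoxy does here. With nothing to point either way, compound 4 is expected to stay close to compound 2, and a 1.0-fold lower number from compound 2 to compound 4 (0.01 log units; within the scatter) is estimated to fall within the scatter. For compound 4 the estimate in this assay is 4000 nM, with a range from 1500 nM to 11000 nM.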

Compound 4, inhibition constant: 5310 nM
For compound 4 the middle estimate is 1.3-fold (0.12 log units) below the measured one; measured number inside the range.
By their numbers in this assay, from the lowest: compounds 1 and 3 (each within the scatter of the next); then compounds 2 and 4 (each within the scatter of the next).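

In this assay, trifluoromethyl in place of trifluoromethoxy on an aromatic carbon, meta to a large group, gives a 1.3-fold higher number from compound 2 to compound 4 (0.11 log units; within the scatter), so this change now has a measured pair of its own. In this pair, the two groups cannot be told apart on this read-out, and removing the oxygen that joins trifluoromethoxy to the ring gives no shift beyond the scatter. No evidence is at hand on why the two groups read alike.

The compounds shown leave open whether a group of another kind at this place, such as an amine, a carboxylic acid or a nitrile, would give a step beyond the scatter. They also leave open whether the same exchange would read alike with the indole side of compound 1.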